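This account rests on a few compounds, and the source may have more. Where it says the series, first, only, none or still open, it means among the compounds named here.

Among the compounds with values here, in a functional assay on MCF7 cells (Homo sapiens) for antiproliferative activity, read by sulforhodamine B assay, with a stated time of 48 h (a lower number here means a stronger inhibitor, a higher number a weaker inhibitor), compound 1 `O=C1NCCN1c1ccc(S(=O)(=O)Nc2ccc(I)cc2)cc1` gives 600 nM, the highest of the three numbers measured so far. Compound 2 `O=C1NCCN1c1ccc(S(=O)(=O)Nc2ccc(Br)cc2)cc1` gives 240 nM, and compound 3 `Cc1ccc(NS(=O)(=O)c2ccc(N3CCNC3=O)cc2)c(C)c1` gives 230 nM. Compound 4 `COc1ccc(NS(=O)(=O)c2ccc(N3CCNC3=O)cc2)cc1` differs from compound 1 by methoxy in place of iodo on an aromatic carbon. Within the data shown here, two measured steps bear on this change. Putting bromo in place of iodo gave a 2.5-fold lower number from compound 1 to compound 2 (0.40 log units; beyond the scatter), and exchanging the whole ring on the sulfonamide nitrogen gave a 2.6-fold lower number from compound 1 to compound 3 (0.42 log units; beyond the scatter); both were modest and both lowered the number. Compound 2 and compound 3 lie within the scatter of each other, with a 1.0-fold lower number from compound 2 to compound 3 (0.02 log units; within the scatter). Removing iodo from the same place is therefore expected to give a modest lowering, a 2.1-fold lower number from compound 1 to compound 4 (0.33 log units; beyond the scatter). Compound 4 is expected to show 280 nM, with a range from 110 nM to 700 nM.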

Compound 4, half-maximal inhibitory concentration: > 1000 nM
Compound 4: a limit, no number; the forecaster's own chance of this, stated with the estimate: 5%; middle value at least 3.5-fold (0.55 log units) from the limit.
By their numbers in this assay, from the lowest: compounds 3 and 2 (each within the scatter of the next); then compound 1. At a limit, above all of these: compound 4.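

Compound 4 gives > 1000 nM, which is a limit and not a number: the limit of > 1000 nM in this assay, at which 1 of the 4 values shown sits. Methoxy in place of bromo gave an at least 4.1-fold higher number from compound 2 to compound 4 (0.61 log units; beyond the scatter), and the change of ring gave an at least 4.3-fold higher number from compound 3 to compound 4 (0.63 log units; beyond the scatter), so a change at this aromatic carbon can raise the number as well as lower it. Against iodo, the result is an at least 1.6-fold higher number from compound 1 to compound 4 (0.22 log units; that floor lies within the scatter), so methoxy is not clearly separated from iodo.

Going by these compounds, how far compound 4 lies beyond that limit remains open. So does how an amine or a carboxylic acid would read on this same carbon.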